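A ring nitrogen replaces the methyl-bearing indazole

The source may hold more compounds than are shown below. What is called first, only, known or untested is meant among the compounds shown, and "the series" means these compounds.

Three ureas sharing one core have been tested in a functional assay on Bel-7402 cells (Homo sapiens) for cytotoxicity, read by MTT assay, with a stated time of 72 h; on this read-out higher numbers stand for weaker inhibition and lower numbers for stronger inhibition. Compound 1 `O=C(Nc1ccc(-n2ncc3c(Cl)cccc32)cc1)Nc1ccc(Cl)c(C(F)(F)F)c1` gives 2500 nM, compound 2 `O=C(Nc1ccc(-n2ncc3c(Br)cccc32)cc1)Nc1ccc(Cl)c(C(F)(F)F)c1` gives 1300 nM, and compound 3 `Cc1cccc2c1cnn2-c1ccc(NC(=O)Nc2ccc(Cl)c(C(F)(F)F)c2)cc1` gives 6700 nM. Compound 3 stands highest of the three: the change was a 2.7-fold higher number from compound 1 to compound 3 (0.43 log units; beyond the scatter) and a 5.2-fold higher number from compound 2 to compound 3 (0.71 log units; beyond the scatter), while a 1.9-fold lower number from compound 1 to compound 2 (0.28 log units; within the scatter).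

Compound 4 `O=C(Nc1ccc(-n2ncc3cnccc32)cc1)Nc1ccc(Cl)c(C(F)(F)F)c1` differs from compound 3 in one place: a group of 9 heavy atoms (6 carbon, 3 nitrogen; one five-membered aromatic ring with 2 hetero atoms, one six-membered aromatic ring with 1 hetero atom) in place of a group of 10 heavy atoms (8 carbon, 2 nitrogen; one five-membered aromatic ring with 2 hetero atoms, one six-membered aromatic ring of carbon only), on an aromatic carbon, on an aromatic carbon of a six-membered aromatic ring of carbon only, para to a large group. Going by the values given here, none of the measured steps bears directly on this exchange; they only vary the group on the indazole, and both measured steps out of compound 3 point toward lower numbers when the methyl is replaced. The new bicycle lacks the methyl and carries a ring nitrogen, so the direction in this assay is uncertain. Compound 4 is therefore expected near the middle of the spread seen so far, with a 1.7-fold lower number from compound 3 to compound 4 (0.22 log units; within the scatter) as the estimated step. For compound 4 the estimate in this assay is 4000 nM, in a range from 1000 nM to 16000 nM.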

Compound 4, half-maximal inhibitory concentration: 2700 nM
Compound 4: middle estimate off by 1.5-fold (0.17 log units), on the high side; the range from low to high includes it.
By their numbers in this assay, from the lowest: compounds 2, 1 and 4 (each within the scatter of the next, the first and the last beyond it); then compound 3.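

In this assay, the step at this place, para to a large group, shows that the whole 4-methyl-1H-indazol-1-yl group can be exchanged, not only its substituent, and that the entering group with a ring nitrogen gives a lower number than the methyl compound (a 2.5-fold lower number from compound 3 to compound 4 (0.39 log units; beyond the scatter)). Set against the halogen compounds, the result divides: the step to the chloro compound stays inside the scatter (a 1.1-fold higher number from compound 1 to compound 4 (0.03 log units; within the scatter)), whereas the bromo compound remains apart (a 2.1-fold higher number from compound 2 to compound 4 (0.32 log units; beyond the scatter)). Nothing shown explains these steps.

As far as these compounds go, compound 4 differs from compound 3 by both the ring nitrogen and the missing methyl, so what each contributes alone stays open. Also open, from the compounds shown here alone, is how a methoxy group or an amine on the entering group would read in this assay.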